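Benzoxazolone carbamates: bromo to nitro on the core

The source may hold more compounds than are shown below. What is called first, only, known or untested is meant among the compounds shown, and "the series" means these compounds.

Measured so far:
- compound 1 `O=C(NCCCCc1ccccc1)n1c(=O)oc2ccc(Br)cc21` gives 22 nM
- compound 2 `O=C(NCCCCCc1ccccc1)n1c(=O)oc2ccccc21` gives 54 nM
- compound 3 `O=C(NCCCCc1ccccc1)n1c(=O)oc2c(Br)cccc21` gives 18 nM

All three numbers come from an assay on HEK293 cells for inhibition of acid ceramidase (Homo sapiens), with a stated time of 10 min; on this read-out lower numbers stand for stronger inhibition and higher numbers for weaker inhibition. Compound 1 stands second highest of the three. Its nearest neighbour is compound 3, whose value lies within the scatter of that of compound 1, so no order between the two can be read. Compound 2 stands furthest away: its higher number lies beyond the scatter of compound 1, so compound 2 does show the weaker inhibition of the pair.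

The next compound is compound 4 `O=C(NCCCCc1ccccc1)n1c(=O)oc2ccc([N+](=O)[O-])cc21`. It differs from compound 1 in one place: nitro in place of bromo on an aromatic carbon. Among the compounds with values here, no two measured compounds differ at this position, so there is no measured step to lean on. The two bromo compounds, compound 1 and compound 3, sit within the scatter of each other, which suggests the core tolerates a substituent at more than one place. On this assay a small step is expected, if any, towards a somewhat higher number: the expected step from compound 1 to compound 4 is a 1.4-fold higher number from compound 1 to compound 4 (0.13 log units; within the scatter). Compound 4 is thus estimated at 30 nM, within the range 8 nM to 120 nM.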

Compound 4, half-maximal inhibitory concentration: 3 nM
For compound 4 the middle estimate is 10-fold (1.00 log units) above the measured one, outside the stated range (below it).
By their numbers in this assay, from the lowest: compound 4; then compounds 3 and 1 (each within the scatter of the next); then compound 2.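

In this assay, within the data shown here, the change from bromo to nitro on this aromatic carbon of the shared core gives a 7.3-fold lower number from compound 1 to compound 4 (0.87 log units; beyond the scatter) and is the first single-place step. What this carbon carries therefore matters: the substituent here can move the number beyond the scatter, which compounds that differ in more than one place, or only in where the bromo sits, could not show. No measurement at hand accounts for this step.

Going by these compounds, it remains open whether the gain belongs to nitro alone or extends to other groups on this carbon, such as a nitrile, an amine or a carboxylic acid. On these data alone, it is also open whether nitro would give a similar step where the bromo of compound 3 sits, or alongside the longer chain of compound 2.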